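Methylsulfanyl in place of ethylamino across two cores

This account rests on a few compounds, and the source may have more. Where it says the series, first, only, none or still open, it means among the compounds named here.

Compound 1 `CSc1nccc2c1ncn2C1O[C@H](CO)[C@@H](O)[C@H]1O` and compound 2 `CCNc1nccc2c1ncn2C1O[C@H](CO)[C@@H](O)[C@H]1O` share one core; compound 3 `CCNc1[nH]ccc2ncnc1-2` and compound 4 `CSc1[nH]ccc2ncnc1-2` share another. In a functional assay (Homo sapiens) for inhibition of Nucleic Acid, tested at 100 uM (a lower number here means less inhibition, a higher number more inhibition at the concentration tested (going by the name of the read-out)), compound 1 gives 24%, compound 2 gives 4% and compound 3 gives 3%. The step of a number 20 percentage points higher from compound 2 to compound 1 (beyond the scatter) follows the change (methylsulfanyl in place of ethylamino on an aromatic carbon). The difference between the cores of compound 2 and compound 3 is not broken down here. Compound 3 and compound 4 differ by methylsulfanyl in place of ethylamino on an aromatic carbon, the same change at a place described in the same words. A step of about a number 15 percentage points higher from compound 3 to compound 4 (beyond the scatter) is expected in this assay, a little smaller than the measured one since it rests on a single instance, the step of a number 20 percentage points higher from compound 2 to compound 1 (beyond the scatter), and on compound 3 giving 3%. Compound 4 is therefore expected at 18% in this assay, between 3% and 38%.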

Compound 4, a percentage reported as inhibition, at one concentration (the size of the read-out at that concentration, not a potency): 4%
Compound 4: middle estimate off by 14 percentage points, on the high side; the measured number falls inside the stated range.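

In this assay methylsulfanyl in place of ethylamino on an aromatic carbon gives a number 1 percentage points higher from compound 3 to compound 4 (within the scatter) and so does not repeat the step seen on the other core. The size of this step differs between the two cores and cannot be carried from one to the other in this series: the same change on two cores in this assay, a number 20 percentage points higher (beyond the scatter) from compound 2 to compound 1 and a number 1 percentage points higher (within the scatter) from compound 3 to compound 4, 19 percentage points apart, beyond the scatter of two such steps
These two pairs do not show which part of the cores goes with the difference, nor how the change behaves on any further core.

Open, from the compounds shown here alone, is whether another group on this aromatic carbon, such as methoxy or a longer chain like propylamino, would give a higher number on the core of compound 3. Also open, going by these compounds, is whether ethylsulfanyl would follow methylsulfanyl on either core.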